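From chloro to phenylethynyl on a shared core

The source may hold more compounds than are shown below. What is called first, only, known or untested is meant among the compounds shown, and "the series" means these compounds.

Measured in a physicochemical assay for lipophilicity, read by HPLC, at pH 7.4; a higher number here means a more lipophilic compound, a lower number a more polar compound:
- compound 1 `Cc1ccccc1C(=O)Nc1cc(Cl)ccn1`: 3.4
- compound 2 `Cc1c(F)cccc1C(=O)Nc1cc(Cl)ccn1`: 2.3
- compound 3 `Cc1ccccc1C(=O)Nc1ccc(F)cn1`: 2.7

Compound 1 stands highest of these three, and its gaps to both others lie beyond the scatter. Compound 4 `Cc1ccccc1C(=O)Nc1cc(C#Cc2ccccc2)ccn1` departs from it in one place, opposite the ring nitrogen: 2-phenylethynyl in place of chloro on an aromatic carbon. Going by the values given here, only one measured step offers any guide: a number 1.10 log units lower from compound 1 to compound 2 (beyond the scatter). That step is large, but it is fluoro in place of hydrogen, a different change, so it bears only loosely on this one. Among the compounds with values here, the entering group holds an aromatic ring of carbon only and a triple bond, and no measured compound carries anything like it. A rise in this assay beyond the scatter is nevertheless expected, an estimated a number 1.00 log units higher from compound 1 to compound 4 (beyond the scatter). Compound 4 is estimated at 4.4, within a range of 3.8 to 5.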

Compound 4, distribution coefficient: 4.7
Beside the measured number, compound 4's estimate is 0.30 log units below it, within the range that was stated.
By their numbers in this assay, from the lowest: compound 2; then compound 3; then compound 1; then compound 4.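

In this assay the change from chloro to 2-phenylethynyl opposite the ring nitrogen gives a number 1.30 log units higher from compound 1 to compound 4 (beyond the scatter) on the shared core. This is the first change shown at this position, and the only earlier step went downward, so the number can clearly climb through a substituent placed here. Nothing measured here accounts for the size of this rise.

The compounds shown do not separate the part played by the triple bond from that of the aromatic ring of carbon only. As far as these compounds go, how an amine, a carboxylic acid or a longer alkyl chain at this position would read also remains open.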